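A few compounds are considered here, and "the series" means these few. Any claim that something is new, unique, unknown or untested is made for them only; others in the source may bear on it.

Values in a functional assay on WHCO1 cells (Homo sapiens) for cytotoxicity, read by MTT assay, with a stated time of 24 h; on this read-out lower numbers stand for stronger inhibition and higher numbers for weaker inhibition:

Compound 1 `CC(O)C1=CC(=O)c2ccccc2C1=O`: 6400 nM
Compound 2 `C=CC(O)C1=CC(=O)c2ccccc2C1=O`: 4300 nM
Compound 3 `O=C1C=C(C(O)c2ccc(Cl)cc2)C(=O)c2ccccc21`: 3000 nM

The three compounds share one core and differ only in the group on a saturated chain carbon bound to a double-bonded ring carbon and an oxygen on a saturated carbon. Compound 3 gives the lowest of the three numbers in this assay. The step of a 2.1-fold lower number from compound 1 to compound 3 (0.33 log units; beyond the scatter) is the only one beyond the scatter; the steps of a 1.5-fold lower number from compound 1 to compound 2 (0.17 log units; within the scatter) and a 1.4-fold lower number from compound 2 to compound 3 (0.16 log units; within the scatter) both stay within it, so compound 3 and compound 2 cannot be ranked against each other.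

Compound 4 `O=C1C=C(C(O)c2ccc(F)cc2)C(=O)c2ccccc21` is the next compound. It differs from compound 3 as follows: fluoro in place of chloro on an aromatic carbon The fluoro sits on an aromatic carbon of a six-membered aromatic ring of carbon only, para to a large group.

Among the measured compounds shown here, no measured step bears directly on this change. The two steps that reach compound 3 each install the whole 4-chlorophenyl in place of a smaller group, and neither separates the chloro from the ring it sits on. The measured pairs give no ground for expecting the halogen swap to move the number beyond the scatter in either direction.

Compound 4 is therefore expected to give about 3500 nM in this assay, with a range of 1800 nM to 7000 nM. That estimate means a step of a 1.2-fold higher number from compound 3 to compound 4 (0.07 log units; within the scatter), expected to lie within the scatter.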

Compound 4, half-maximal inhibitory concentration: 5100 nM
Compound 4: middle estimate off by 1.5-fold (0.16 log units), on the low side; measured number inside the range.
By their numbers in this assay, from the lowest: compounds 3, 2, 4 and 1 (each within the scatter of the next, the first and the last beyond it).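

In this assay, among the compounds shown here, the halogen swap is the first change away from the saturated chain carbon, on an aromatic carbon para to a large group, and it gives a 1.7-fold higher number from compound 3 to compound 4 (0.23 log units; within the scatter) so that the halogen at this place cannot be said to matter on these numbers alone. For the compounds shown here, it also changes how the aryl step reads: 4-chlorophenyl in place of methyl gave a 2.1-fold lower number from compound 1 to compound 3 (0.33 log units; beyond the scatter) as the only step beyond the scatter, while 4-fluorophenyl in place of methyl gives only a 1.3-fold lower number from compound 1 to compound 4 (0.10 log units; within the scatter) and 4-fluorophenyl in place of vinyl gives a 1.2-fold higher number from compound 2 to compound 4 (0.07 log units; within the scatter) with neither of these two leaving the scatter, so the one clear step among the aryl compounds rests on the chloro compound alone. Nothing available accounts for these numbers.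

The compounds shown leave open whether a bromo or a methoxy on that aromatic carbon, or a plain phenyl with no halogen at all, would give a step beyond the scatter. They also leave open what a longer chain on the saturated chain carbon, or an amine in place of its oxygen, would do in this assay on this shared core.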